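The source may report more compounds than this note shows. Statements on the series, on what has been measured and on what is new or still open speak of the compounds shown alone.

Of the compounds shown here, three built on one shared core have been measured in a functional assay on the whole organism for inhibition, with Brassica napus as the target, with a stated time of 72 h, tested at 100 mg/L; on this read-out lower numbers stand for less inhibition of growth and higher numbers for more inhibition of growth at the one concentration tested. Compound 1 `COc1cc(C)nc(NC(=S)NC(=O)c2c(-c3ccc(Cl)cc3Cl)noc2C)n1` gives 69.3%, compound 2 `CSc1cc(C)nc(NC(=S)NC(=O)c2c(-c3ccc(Cl)cc3Cl)noc2C)n1` gives 73.6%, and compound 3 `Cc1cc(C)nc(NC(=S)NC(=O)c2c(-c3ccc(Cl)cc3Cl)noc2C)n1` gives 68%. Compound 3 holds the lowest of the three numbers, yet all three sit within the scatter of one another: a number 1.3 percentage points lower from compound 1 to compound 3 (within the scatter), a number 5.6 percentage points lower from compound 2 to compound 3 (within the scatter) and a number 4.3 percentage points higher from compound 1 to compound 2 (within the scatter). Compound 4 `COc1cc(OC)nc(NC(=S)NC(=O)c2c(-c3ccc(Cl)cc3Cl)noc2C)n1` has not yet been measured; it carries 4,6-dimethoxypyrimidin-2-yl in place of 4,6-dimethylpyrimidin-2-yl on an amide-type nitrogen. The closest guide is the step of a number 1.3 percentage points lower from compound 1 to compound 3 (within the scatter), a methyl in place of a methoxy on an aromatic carbon. Within the data shown here, since no measured step reaches beyond the scatter, no step beyond the scatter is expected here either. Compound 4 is therefore expected to give 68%, between 55% and 80%. The estimated step is no change at the digits printed from compound 3 to compound 4 (within the scatter).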

Compound 4, percent growth inhibition at one concentration: 70.8%
Compound 4: middle estimate off by 2.8 percentage points, on the low side; low and high end bracket the measured number.
By their numbers in this assay, from the lowest: compounds 3, 1, 4 and 2 (each within the scatter of the next).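

In this assay, placing 4,6-dimethoxypyrimidin-2-yl on the amide-type nitrogen leaves the read-out within the scatter against all three earlier groups (a number 2.8 percentage points higher from compound 3 to compound 4 (within the scatter); a number 2.8 percentage points lower from compound 2 to compound 4 (within the scatter); a number 1.5 percentage points higher from compound 1 to compound 4 (within the scatter)). Two methoxy groups thus fare no differently here from one methoxy, methylsulfanyl or methyl alongside methyl, and the four compounds remain unseparated. No evidence bears on why this is so. From the compounds shown here alone, it remains open whether an amine or a longer alkoxy chain in place of methoxy would produce a step beyond the scatter.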